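Removing a Fluoro Group from an Amidine Biaryl Thiophene

The source may hold more compounds than are shown below. What is called first, only, known or untested is meant among the compounds shown, and "the series" means these compounds.

Compound 1, `COc1cc(OC)cc(-c2ccc(-c3ccc(C(=N)N)c(F)c3)s2)c1`, gives 173 nM in a functional assay on HCT-116 cells (Homo sapiens) for inhibition, read by sulforhodamine B assay, with a stated time of 48 h; on this read-out higher numbers stand for weaker inhibition of growth and lower numbers for stronger inhibition of growth. Compound 2, `N=C(N)c1ccc(-c2ccc(-c3ccc(Cl)cc3)s2)cc1F`, gives 171 nM in this assay. Compound 3, `N=C(N)c1ccc(-c2ccc(-c3ccc(Cl)cc3)s2)cc1`, gives 170 nM in this assay.

All three measured compounds share an amidine-bearing biaryl thiophene core and differ only in small details. Compound 1 and compound 2 have different cores, but that difference between the two cores is not broken down here; their values lie within the usual scatter of each other. Compound 2 and compound 3 differ by a single change, (hydrogen in place of fluoro on an aromatic carbon), and this change made a 1.0-fold lower number from compound 2 to compound 3 (0.00 log units; within the scatter).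

Compound 4, `COc1cc(OC)cc(-c2ccc(-c3ccc(C(=N)N)cc3)s2)c1`, has not yet been measured. It arises from compound 1 by hydrogen in place of fluoro on an aromatic carbon, the same change at the same kind of place as from compound 2 to compound 3. Because that earlier change gave a 1.0-fold lower number from compound 2 to compound 3 (0.00 log units; within the scatter), the expected step is a 1.0-fold lower number from compound 1 to compound 4 (0.01 log units; within the scatter), with no shift beyond the scatter. The estimated value for compound 4 in this assay is therefore 170 nM, likely between 85 nM and 340 nM.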

Compound 4, concentration for 50% growth inhibition: 1760 nM
Compound 4: middle estimate off by 10-fold (1.02 log units), on the low side; the measured number lies above the stated range.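

In this assay, replacing the fluoro with hydrogen did not have the same outcome on the two cores. Here the swap gave a 10-fold higher number from compound 1 to compound 4 (1.01 log units; beyond the scatter), which means weaker inhibition of growth, while on the chloro-bearing core it left no difference beyond the scatter, and the two steps clearly disagree: the same change on two cores in this assay, a 1.0-fold lower number (0.00 log units; within the scatter) from compound 2 to compound 3 and a 10-fold higher number (1.01 log units; beyond the scatter) from compound 1 to compound 4, 10-fold (1.01 log units) apart, beyond the scatter of two such steps. This shows that, in this series, the result of this change on one core cannot simply be carried over to the other, but two pairs of compounds do not show why the cores respond differently or which part of the core decides the outcome.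

Going by these compounds, it remains open whether a methyl group or a hydroxyl group in the place of the fluoro would keep the stronger inhibition seen with compound 1. Also open, on these data alone, is how a core with only one of the two methoxy groups would respond to the same swap, which could help show whether both are tied to the large step.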